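The source may report more compounds than this note shows. Statements on the series, on what has been measured and on what is new or still open speak of the compounds shown alone.

Measured compounds:
- compound 1, `CSc1nc2c(N)ncnc2n1[C@@H]1O[C@@H]2COP(=O)(O)O[C@H]2[C@H]1O`: 645%
- compound 2, `Nc1ncnc2c1nc(O)n2[C@@H]1O[C@@H]2COP(=O)(O)O[C@H]2[C@H]1O`: 114%

Both compounds share the same core and were tested in a functional assay on the whole organism for activation, with Mus musculus as the target, with stated times of 14 days and 2 h, at a dose of 15 mg/kg by the intravenous route; a higher number here means a stronger effect of the compound at the dose given, a lower number a weaker effect. Compound 1 gives 645% in this assay, and compound 2 gives 114%. Of the two numbers, compound 2 stands lowest; its nearest neighbour is compound 1, with a step of a number 531 percentage points lower from compound 1 to compound 2 (beyond the scatter), a large drop that is beyond the scatter.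

Compound 3, `[N-]=[N+]=Nc1nc2c(N)ncnc2n1[C@@H]1O[C@@H]2COP(=O)(O)O[C@H]2[C@H]1O`, has not yet been measured in this assay. It differs from compound 2 in one place: azido in place of hydroxy on an aromatic carbon. Going by the values given here, the only measured step that bears on this change is the step from compound 1 to compound 2, in which a hydroxy group replaced methylsulfanyl and the number fell by a number 531 percentage points lower from compound 1 to compound 2 (beyond the scatter). That step shows that the hydroxy compound is far weaker than its methylsulfanyl counterpart at this place; it does not show directly how an azido group behaves there. Since compound 3 again removes the hydroxy group, an increase in this assay is expected, though its size is uncertain, with an estimated step of a number 236 percentage points higher from compound 2 to compound 3 (beyond the scatter). Compound 3 is therefore estimated at 350%, within a range from 110% to 650%.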

Compound 3, a percentage reported as activity, at one dose (the size of the read-out at that dose, not a potency): 594%
Compound 3: the middle estimate sits 244 percentage points below what was measured; the range from low to high includes it.
By their numbers in this assay, from the lowest: compound 2; then compound 3; then compound 1.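

In this assay, the change to azido in place of hydroxy gives a number 480 percentage points higher from compound 2 to compound 3 (beyond the scatter) and thus reverses most of the earlier loss. The low number of compound 2 therefore does not come with every replacement of methylsulfanyl on this aromatic carbon between two ring nitrogen atoms, and a group quite different from methylsulfanyl can also give a high read-out. Even so, azido does not fully match methylsulfanyl, since the direct comparison gives a number 51 percentage points lower from compound 1 to compound 3 (beyond the scatter) in the same assay, and nothing measured here explains the differences among these groups.

From the compounds shown here alone, with only hydroxy, methylsulfanyl and azido at this place, it remains open which feature of a group sets the read-out, and whether an amine, a methoxy group or a longer sulfur-linked chain such as benzylsulfanyl would follow azido and methylsulfanyl or fall towards hydroxy. Each compound also appears at a single dose, so these numbers leave open how the three would compare at other doses and whether the order of the groups would hold there.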